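A few compounds are considered here, and "the series" means these few. Any claim that something is new, unique, unknown or untested is made for them only; others in the source may bear on it.

Compound 1 `Cn1nccc1-c1cc(C(F)(F)F)ccc1[C@H]1CCOc2cc(S(=O)(=O)Nc3cccc(F)n3)ccc21`: 3.6
Compound 2 `Cn1nccc1-c1cc(C(F)(F)F)ccc1[C@H]1CCOc2cc(S(=O)(=O)Nc3ccc(F)cn3)ccc21`: 3.8

In a physicochemical assay for lipophilicity (a lower number here means a more polar compound, a higher number a more lipophilic compound), compound 2 gives 3.8, which lies within the scatter of compound 1. Among the measured compounds shown here, the only measured step is a number 0.20 log units higher from compound 1 to compound 2 (within the scatter), and it merely exchanges one fluoropyridinyl group for another. Compound 3 `Cn1nccc1-c1cc(C(F)(F)F)ccc1[C@H]1CCOc2cc(S(=O)(=O)Nc3cnccn3)ccc21` has pyrazin-2-yl in place of 5-fluoropyridin-2-yl on a sulfonamide nitrogen. For the measured compounds named here, no measured step involves pyrazin-2-yl, so the size of this change remains uncertain, although a lower number in this assay is expected. The expected step is a number 0.70 log units lower from compound 2 to compound 3 (beyond the scatter). Compound 3 is estimated at 3.1, with an expected range from 2.6 to 3.6.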

Compound 3, distribution coefficient: 1.8
Beside the measured number, compound 3's estimate is 1.30 log units above it, outside the stated range (below it).
By their numbers in this assay, from the lowest: compound 3; then compounds 1 and 2 (each within the scatter of the next).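

In this assay the ring on the sulfonamide nitrogen proves able to move the number far more than the exchange between the two fluoropyridinyl groups did: pyrazin-2-yl gives a number 2.00 log units lower from compound 2 to compound 3 (beyond the scatter) and also a number 1.80 log units lower from compound 1 to compound 3 (beyond the scatter) when it replaces the other fluoropyridinyl group. The large drop therefore appears from both starting points. Nothing at hand explains its size. From the compounds shown here alone, the change removes the fluorine and adds a second ring nitrogen at once, so their separate shares stay open, as does how a plain pyridin-2-yl or a pyrimidin-4-yl group on this nitrogen would read in this assay by comparison.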